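The source may report more compounds than this note shows. Statements on the series, on what has been measured and on what is new or still open speak of the compounds shown alone.

Of the compounds shown here, three have been measured so far in a functional assay on A549 cells (Homo sapiens) for antiproliferative activity, read by MTT assay, with a stated time of 48 h; on this read-out higher numbers stand for weaker inhibition and lower numbers for stronger inhibition. Compound 1 `COc1ccc(C(=O)c2ccc3c(c2)C=CC(C)(C)O3)c(NC(=O)CBr)c1` gives 1980 nM there and compound 2 `COc1ccc(C(=O)c2ccc(OC)c3c2C=CC(C)(C)O3)c(NC(=O)CN)c1` gives 420 nM there, while compound 3 `C=C(c1ccc(OC)cc1NC(=O)CN)c1ccc(OC)c2c1OC(C)(C)C=C2` gives 50 nM and so holds the lowest number of the three. Its gaps to compound 2 and to compound 1 both lie beyond the scatter of repeated measurements. No two of these compounds differ in one place only, so the data hold no direct measure of what a change on the amino group does.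

Compound 4 `C=C(c1ccc(OC)cc1NC(=O)CN(C)C)c1ccc(OC)c2c1OC(C)(C)C=C2` has not yet been measured. It departs from compound 3 by one change (dimethylamino in place of amino on a saturated chain carbon bound to a carbonyl carbon): dimethylamino in place of amino on a saturated chain carbon bound to a carbonyl carbon. Everything else stays as it is in compound 3. Among the compounds with values here, with no measured precedent for this change, the expectation rests on compound 3 at 50 nM and no step beyond the scatter is foreseen, with a slight lean towards a higher number. In this assay the expected step is a 1.6-fold higher number from compound 3 to compound 4 (0.20 log units; within the scatter) and it remains an estimate. For compound 4 the estimated value is 80 nM with an expected range from 20 nM to 300 nM in this read-out.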

Compound 4, half-maximal inhibitory concentration: 270 nM
Beside the measured number, compound 4's estimate is 3.4-fold (0.53 log units) below it, within the range that was stated.
By their numbers in this assay, from the lowest: compound 3; then compounds 4 and 2 (each within the scatter of the next); then compound 1.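

Within the data shown here, the first direct reading at this position comes from replacing amino with dimethylamino on a saturated chain carbon bound to a carbonyl carbon: in this assay this change gives a 5.4-fold higher number from compound 3 to compound 4 (0.73 log units; beyond the scatter), a modest step. The position is therefore not indifferent to this change, and here the larger group goes with weaker inhibition, as amino, with 1 heavy atom and 1 hydrogen-bond donor, gives way to dimethylamino, with 3 heavy atoms and 0 hydrogen-bond donors. No measurement at hand accounts for the step.

The compounds shown leave open whether the added heavy atoms or the lost hydrogen-bond donor matter more, and methylamino, which would keep a donor while adding a single methyl, would be the natural group to tell these apart. They also leave open how a ring amine such as morpholine or a longer chain carrying the amino group would read at this position, and whether dimethylamino would give a step of similar size on the core of compound 2.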